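This account rests on a few compounds, and the source may have more. Where it says the series, first, only, none or still open, it means among the compounds named here.

Three measured members share one core: compound 1 `COc1ccc(S(=O)(=O)c2cnc3ccc(C)cc3c2N2CCC(C)CC2)cc1`, compound 2 `Cc1ccc2ncc(S(=O)(=O)c3ccc(C)c(Cl)c3)c(N3CCC(C)CC3)c2c1` and compound 3 `Cc1ccc2ncc(S(=O)(=O)c3ccccc3)c(N3CCC(C)CC3)c2c1` differ only in the aryl group on the sulfonyl sulfur. In an assay on isolated protein for displacement of a labelled ligand from metabotropic glutamate receptor 5 (Homo sapiens), with a stated time of 60 min, tested at 1 uM (a higher number here means more inhibition at the concentration tested (going by the name of the read-out), a lower number less inhibition), compound 1 gives 62%, compound 2 gives 91% and compound 3 gives 67%. Compound 3 stands second highest of the three values, separated from the nearest by a number 5 percentage points higher from compound 1 to compound 3 (within the scatter) and from the furthest by a number 24 percentage points lower from compound 2 to compound 3 (beyond the scatter). Compound 4 `Cc1ccc(S(=O)(=O)c2cnc3ccc(C)cc3c2N2CCC(C)CC2)cc1` carries methyl in place of hydrogen on an aromatic carbon. Among the compounds with values here, two steps bear on this. Hydrogen in place of methoxy on an aromatic carbon gave a number 5 percentage points higher from compound 1 to compound 3 (within the scatter); phenyl in place of 3-chloro-4-methylphenyl gave a number 24 percentage points lower from compound 2 to compound 3 (beyond the scatter). A methyl alone is expected to recover only part of the latter gain, so a step of a number 7 percentage points higher from compound 3 to compound 4 (within the scatter) is estimated. Compound 4 is expected near 74%, between 60% and 88%.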

Compound 4, a percentage reported as inhibition, at one concentration (the size of the read-out at that concentration, not a potency): 82%
Estimate against measurement, compound 4: 8 percentage points below, within the range that was stated.
By their numbers in this assay, from the lowest: compounds 1 and 3 (each within the scatter of the next); then compounds 4 and 2 (each within the scatter of the next).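

Methyl para to a large group moves the number on its own, as phenyl to 4-methylphenyl gives a number 15 percentage points higher from compound 3 to compound 4 (beyond the scatter), whereas methoxy there could not be told from hydrogen, and the two groups now separate with a number 20 percentage points higher from compound 1 to compound 4 (beyond the scatter). The chloro of the 3-chloro-4-methylphenyl group adds nothing separable beyond the methyl, with hydrogen in its place giving a number 9 percentage points lower from compound 2 to compound 4 (within the scatter). No measurement shown accounts for the difference between methyl and methoxy.

Open, as far as these compounds go, is whether an ethyl, a fluoro or an amine in that place holds the number. Also open, from the compounds shown here alone, is whether the methyl step carries over when other parts of the shared core change.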